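Methoxycarbonyl Out, Cyano In: Expecting Somewhat Lower Lipophilicity

The source may report more compounds than this note shows. Statements on the series, on what has been measured and on what is new or still open speak of the compounds shown alone.

Three measured compounds share one core. In a physicochemical assay for lipophilicity (on this read-out higher numbers stand for higher lipophilicity and lower numbers for lower lipophilicity), compound 1 `COC(=O)c1sc(Oc2ccccc2)c(C#N)c1N` gives 3.66, compound 2 `COC(=O)c1sc(Oc2cccc(C)c2)c(C#N)c1N` gives 4.16, and compound 3 `N#Cc1c(Oc2ccccc2)sc(C(=O)c2ccc([N+](=O)[O-])cc2)c1N` gives 4.53. Compound 2 therefore stands second highest of the three, with compound 3 above it and compound 1 below it. Among the measured compounds shown here, the only single-point step measured so far, a number 0.50 log units higher from compound 1 to compound 2 (beyond the scatter), concerns a methyl added on an aromatic carbon and does not touch the change now in question. Compound 4 `Cc1cccc(Oc2sc(C#N)c(N)c2C#N)c1` differs from compound 2 by cyano in place of methoxycarbonyl on an aromatic carbon. For the measured compounds named here, no measured step bears on this swap, so the expectation carries a wide range. Compound 4 is estimated at 3.7, between 3.2 and 4.2. The expected step is a number 0.46 log units lower from compound 2 to compound 4 (beyond the scatter), a modest fall in this assay.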

Compound 4, partition coefficient: 3.04
For compound 4 the middle estimate is 0.66 log units above the measured one; the measured number lies below the stated range.
By their numbers in this assay, from the lowest: compound 4; then compound 1; then compound 2; then compound 3.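

Among the compounds shown here, at this position, next to the ring sulfur, swapping methoxycarbonyl for cyano has a large effect: this assay records a number 1.12 log units lower from compound 2 to compound 4 (beyond the scatter) as the first measured step here. The earlier methyl step lay elsewhere on the molecule and gave no sign of how much this position could shift the number. Nothing measured here explains the size of this fall.

From the compounds shown here alone, it remains open whether an ethyl ester or a carboxylic acid here would land nearer compound 2 or compound 4. Going by these compounds, whether the same swap gives a similar step without the methyl, on the core of compound 1, also remains open.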